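The source may report more compounds than this note shows. Statements on the series, on what has been measured and on what is new or still open speak of the compounds shown alone.

Measured compounds:
compound 1 `O=C(COCc1cccnc1)N1CCN(c2ccc(Cl)cc2Cl)CC1`, 1090 nM
compound 2 `O=C(COCc1cnccn1)N1CCN(c2ccc(Cl)cc2Cl)CC1`, 5200 nM
compound 3 `O=C(COCc1ccncn1)N1CCN(c2ccc(Cl)cc2Cl)CC1`, 2800 nM

All three share one core and differ only in the aromatic ring hung on the chain. In a functional assay on HEK293 cells for positive allosteric modulation of metabotropic glutamate receptor 5 (Homo sapiens), read by FLIPR and calcium flux (a lower number here means that less compound is needed, a higher number that more compound is needed for the effect), compound 3 gives 2800 nM, the second highest number of the three: its gap to compound 2 is within the scatter, a 1.9-fold lower number from compound 2 to compound 3 (0.27 log units; within the scatter), while compound 1 sits clearly lower, a 2.6-fold higher number from compound 1 to compound 3 (0.41 log units; beyond the scatter).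

Compound 4 `O=C(COCc1cscn1)N1CCN(c2ccc(Cl)cc2Cl)CC1` is not yet measured. Its change from compound 3 is 1,3-thiazol-4-yl in place of pyrimidin-4-yl on a saturated chain carbon bound to an oxygen on a saturated carbon. Going by the values given here, no measured step swaps a six-membered ring for a five-membered one, so the three known steps bear only loosely on it. They show that changing this ring moves the number by modest amounts: a 4.8-fold higher number from compound 1 to compound 2 (0.68 log units; beyond the scatter), a 2.6-fold higher number from compound 1 to compound 3 (0.41 log units; beyond the scatter), and a 1.9-fold lower number from compound 2 to compound 3 (0.27 log units; within the scatter). A step of similar size is therefore expected here, most likely a small one, with the direction uncertain. Compound 4 is estimated at 2000 nM, between 600 nM and 7000 nM, which means an expected step of a 1.4-fold lower number from compound 3 to compound 4 (0.15 log units; within the scatter).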

Compound 4, half-maximal effective concentration: 290 nM
Compound 4: the middle estimate sits 6.9-fold (0.84 log units) above what was measured; the measured number lies below the stated range.
By their numbers in this assay, from the lowest: compound 4; then compound 1; then compounds 3 and 2 (each within the scatter of the next).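

Putting 1,3-thiazol-4-yl on this saturated chain carbon gives the lowest number of the series in this assay and improves on every other ring: the steps are a 9.7-fold lower number from compound 3 to compound 4 (0.98 log units; beyond the scatter) and an 18-fold lower number from compound 2 to compound 4 (1.25 log units; beyond the scatter) and a 3.8-fold lower number from compound 1 to compound 4 (0.58 log units; beyond the scatter) in turn. The only five-membered aromatic ring in the set therefore outperforms all three six-membered ones, even though it has as many hetero atoms and hydrogen-bond acceptors as the pyrimidin-4-yl it replaces, and a change at this position can shift the number further than the six-membered rings alone showed. No measurement shown explains this gain.

Still open, as far as these compounds go, is whether the gain belongs to the five-membered ring itself or to its sulfur atom. A 1,3-oxazol-4-yl ring, with oxygen in place of sulfur, or a thiophene ring, without the nitrogen, would help separate the two.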